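Aryl change on the core amine: compound 3 to compound 4

The source may hold more compounds than are shown below. What is called first, only, known or untested is meant among the compounds shown, and "the series" means these compounds.

Compound 1 `CN(c1ncccc1CNc1nc(Nc2ccc(F)cc2)nc2[nH]cc(F)c12)S(C)(=O)=O` in a functional assay on SMMC-7721 cells (Homo sapiens) for inhibition, read by MTT assay, with a stated time of 48 h (a higher number here means a weaker inhibitor, a lower number a stronger inhibitor), gives 27900 nM. Compound 2 `CN(c1ncccc1CNc1nc(Nc2ccc(F)c(Cl)c2)nc2[nH]cc(F)c12)S(C)(=O)=O` carries chloro in place of hydrogen on an aromatic carbon and in this assay reaches only a limit, > 100000 nM. Compound 3 `COc1cc(Nc2nc(NCc3cccnc3N(C)S(C)(=O)=O)c3c(F)c[nH]c3n2)cc(OC)c1OC` likewise sits at a limit in this assay, > 100000 nM. Two of the three values shown are limits, as the limit of > 100000 nM in this assay, at which 2 of the 3 values shown sit, records, so compound 3 stands at the top of the range and its standing is known only as a bound. The step of an at least 3.5-fold higher number from compound 1 to compound 2 (0.55 log units; beyond the scatter) and the step of an at least 3.5-fold higher number from compound 1 to compound 3 (0.55 log units; beyond the scatter) are both readable only as lower bounds, while the step that the two limits leave unreadable from compound 2 to compound 3 cannot be read at all. Compound 4 `COc1cccc(Nc2nc(NCc3cccnc3N(C)S(C)(=O)=O)c3c(F)c[nH]c3n2)c1C` differs from compound 3 by 3-methoxy-2-methylphenyl in place of 3,4,5-trimethoxyphenyl on a nitrogen on an aromatic ring. Among the compounds with values here, the step that bears on this change is the one from compound 1 to compound 3, since both alter the aryl on the same nitrogen; it was at least modest and upward. The present change moves to a smaller aryl, nearer to compound 1, which gives 27900 nM. The expected step of an at least 1.6-fold lower number from compound 3 to compound 4 (0.22 log units; that floor lies within the scatter) is therefore downward but uncertain, and may stay at the limit. For compound 4 the estimate in this assay is 60000 nM, within 15000 nM to 200000 nM.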

Compound 4, half-maximal inhibitory concentration: > 100000 nM
Compound 4 gave a limit, no number (the forecaster's own chance of this, stated with the estimate: 50%); middle value at least 1.6-fold (0.22 log units) from the limit.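

In this assay, compound 4 gives > 100000 nM, which is a limit and not a number. Replacing 3,4,5-trimethoxyphenyl with 3-methoxy-2-methylphenyl therefore yields no readable value, and the comparison with 4-fluorophenyl is an at least 3.5-fold higher number from compound 1 to compound 4 (0.55 log units; beyond the scatter), so among the aryl groups shown on this nitrogen only compound 1 gives a number; the steps to compound 4 from compound 2 and compound 3 cannot be read. The series now crowds at the top of the range: the limit of > 100000 nM in this assay, at which 3 of the 4 values shown sit.

Going by these compounds, how far compound 2, compound 3 and compound 4 lie past the limit stays unknown, so no order among their aryl groups can be drawn. Also open, on these data alone, is whether an aryl group on this nitrogen carrying an amine or a carboxylic acid would give a lower number than compound 1, at 27900 nM.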